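The source may hold more compounds than are shown below. What is called first, only, known or untested is meant among the compounds shown, and "the series" means these compounds.

In a functional assay on HCT-116 cells (Homo sapiens) for antiproliferative activity, read by MTT assay, with a stated time of 72 h (on this read-out higher numbers stand for weaker inhibition and lower numbers for stronger inhibition), compound 1 `O=C(CCc1cccc2c1B(O)OC2)Nc1ccc(Br)cc1` gives 46000 nM and compound 2 `O=C(CCc1cccc2c1B(O)OC2)Nc1ccc(I)cc1` gives 50000 nM. Swapping one halogen for the other therefore changes little (a 1.1-fold higher number from compound 1 to compound 2 (0.04 log units; within the scatter)). Compound 3 `O=C(CCc1cccc2c1B(O)OC2)Nc1cccc(I)c1` gives 2300 nM, the lowest number of the three and thus the strongest inhibition so far. The most direct comparison keeps iodo and changes only its place on the ring (a 22-fold lower number from compound 2 to compound 3 (1.34 log units; beyond the scatter)). The comparison with the bromo compound is of similar size (a 20-fold lower number from compound 1 to compound 3 (1.30 log units; beyond the scatter)).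

Compound 4 `O=C(CCc1cccc2c1B(O)OC2)Nc1cccc(-c2ccc(F)cc2)c1` keeps the place that served compound 3 but carries 4-fluorophenyl in place of iodo on an aromatic carbon. Among the compounds with values here, no measured step replaces a halogen with a ring, so the data give no direction for this change. The large steps show only that the result can shift sharply with a change on this ring. The best guess is therefore no clear change, with wide uncertainty, and the expected step is small (a 1.3-fold higher number from compound 3 to compound 4 (0.12 log units; within the scatter)). For compound 4 the estimated value is 3000 nM, with an expected range from 700 nM to 15000 nM.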

Compound 4, half-maximal inhibitory concentration: 550 nM
The estimate for compound 4 lay 5.5-fold (0.74 log units) above the measured number, and the stated range ends above it.
By their numbers in this assay, from the lowest: compound 4; then compound 3; then compounds 1 and 2 (each within the scatter of the next).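

In this assay, the place on the ring that already served iodo also accepts a far larger group: 4-fluorophenyl, with 7 heavy atoms and a six-membered aromatic ring, replaces a single iodine atom, giving a 4.2-fold lower number from compound 3 to compound 4 (0.62 log units; beyond the scatter). The number goes down rather than up, so within this small set, a single halogen is not the limit of what this place can carry. Nothing measured here explains why this swap lowers the number.

The compounds shown leave open whether the drop comes from the added ring itself or from the fluorine on it, a question that plain phenyl at this place would address. They also leave open how an amine or a carboxylic acid on the added ring would change the number.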